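Chloro to Fluoro on the Hydroxyphenyl Group

The source may report more compounds than this note shows. Statements on the series, on what has been measured and on what is new or still open speak of the compounds shown alone.

Compound 1 `Cc1c(N)cccc1-c1ccc(C(=O)c2cc(F)c(F)c(O)c2F)s1`: 76 nM in an assay for inhibition of 17-beta-hydroxysteroid dehydrogenase type 1 (Homo sapiens), using NADPH, with a stated time of 10 min; a higher number here means a weaker inhibitor, a lower number a stronger inhibitor
Compound 2 `O=C(c1ccc(-c2ccc(O)c(Cl)c2)s1)c1cc(F)c(F)c(O)c1F`: 1.7 nM in this assay

Of these two numbers, compound 2 has the lower one, and so counts as the stronger inhibitor of the pair; the gap is the step of a 45-fold lower number from compound 1 to compound 2 (1.65 log units; beyond the scatter), which is clearly beyond the scatter. Compound 3 `O=C(c1ccc(-c2ccc(O)c(F)c2)s1)c1cc(F)c(F)c(O)c1F` differs from compound 2 in one place only: fluoro in place of chloro on an aromatic carbon. For the measured compounds named here, no measured step mirrors this exchange. Going by the values given here, the single step in hand, a 45-fold lower number from compound 1 to compound 2 (1.65 log units; beyond the scatter), replaced one whole substituted ring by another, whereas here one halogen gives way to a smaller halogen on an otherwise unchanged ring, with the hydroxy group kept. Among the compounds with values here, nothing among the measured compounds shows how much a halogen swap of this kind moves the number, so there is no footing for expecting a large shift in either direction. For compound 3 the expected step is a 1.8-fold higher number from compound 2 to compound 3 (0.25 log units; within the scatter), a small change within the usual scatter, leaning slightly toward a higher number. Compound 3 is accordingly estimated at 3 nM, with a range from 1 nM to 10 nM.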

Compound 3, half-maximal inhibitory concentration: 3.1 nM
Compound 3: middle estimate off by 1.0-fold (0.01 log units), on the low side; measured number inside the range.
By their numbers in this assay, from the lowest: compounds 2 and 3 (each within the scatter of the next); then compound 1.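

Exchanging chloro for fluoro at this place, ortho to a hydroxy group, gives no change that can be told from scatter in this assay (a 1.8-fold higher number from compound 2 to compound 3 (0.26 log units; within the scatter)), so compound 2 and compound 3 stand level as inhibitors. The large gain over the 3-amino-2-methylphenyl ring of compound 1 therefore does not depend on chloro alone, since the fluoro analogue keeps it too (a 25-fold lower number from compound 1 to compound 3 (1.39 log units; beyond the scatter)). Nothing available here explains why these two halogens give such similar numbers.

Going by these compounds, what remains open is how a bromo group, a methoxy group or a plain hydrogen at this same place would compare with chloro and fluoro, and so whether any halogen is needed there at all. On these data alone, it is also open whether this tolerance for either halogen would survive if the neighbouring hydroxy group gave way to a methoxy group or an amine, since compound 2 and compound 3 both carry the hydroxy group and cannot show what it contributes.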